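This account rests on a few compounds, and the source may have more. Where it says the series, first, only, none or still open, it means among the compounds named here.

Working notes on the selenium-bearing series in a functional assay on MCF7 cells (Homo sapiens) for cytotoxicity, read by MTT assay, with a stated time of 72 h; on this read-out higher numbers stand for weaker inhibition of growth and lower numbers for stronger inhibition of growth. Compound 3 `Nc1nc([SeH])nc2ccccc12` gives 150 nM, the lowest number among the three measured, and both others lie beyond the scatter from it. Compound 2 `CSc1ccc(CNc2nc([SeH])nc3ccccc23)cc1` gives 48100 nM; compound 1 `CCCCC[Se]c1nc(NCc2ccc(SC)cc2)c2ccccc2n1` gives 34700 nM. The difference between the cores of compound 3 and compound 2 is not broken down here. Compound 1 arises from compound 2 by pentyl in place of hydrogen on a selenium, and this gives a 1.4-fold lower number from compound 2 to compound 1 (0.14 log units; within the scatter). Compound 4 `CCCCC[Se]c1nc(N)c2ccccc2n1` is the unmeasured counterpart, arising from compound 3 by pentyl in place of hydrogen on a selenium, the same kind of change at a place described in the same words. Because a 1.4-fold lower number from compound 2 to compound 1 (0.14 log units; within the scatter) lay within the scatter, the expected step for compound 4 is a 1.2-fold lower number from compound 3 to compound 4 (0.06 log units; within the scatter), with no reason to expect more. Compound 4 is therefore estimated at 130 nM, between 45 nM and 450 nM.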

Compound 4, concentration for 50% growth inhibition: 28600 nM
The estimate for compound 4 lay 220-fold (2.34 log units) below the measured number; measured number outside the range, above it.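

In this assay, pentyl in place of hydrogen on a selenium gives a 190-fold higher number from compound 3 to compound 4 (2.28 log units; beyond the scatter), and the same change does not carry over between the two cores: the same change on two cores in this assay, a 1.4-fold lower number (0.14 log units; within the scatter) from compound 2 to compound 1 and a 190-fold higher number (2.28 log units; beyond the scatter) from compound 3 to compound 4, 260-fold (2.42 log units) apart, beyond the scatter of two such steps

For these two pairs, the step read on one core therefore gives no usable estimate for the other. The pairs do not show which part of the difference between the cores accounts for this, and two cores with a single chain support no general rule for the series.

The compounds shown leave open whether methyl or a longer chain such as octyl on the selenium would separate the two cores in the same way. On these data alone, it also remains open whether an acetyl group there would do so.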